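Halogenated aryl groups versus trimethoxyphenyl on the hydrazone

The source may hold more compounds than are shown below. What is called first, only, known or untested is meant among the compounds shown, and "the series" means these compounds.

Measured compounds:
Compound 1, `CN(C)CCn1cnnc1-c1cc(Oc2ccc(NC(=O)N/N=C/c3c(Cl)cccc3Cl)cc2F)ccn1`, 280 nM
Compound 2, `CN(C)CCn1cnnc1-c1cc(Oc2ccc(NC(=O)N/N=C/c3ccc(O)c(Br)c3)cc2F)ccn1`, 450 nM
Compound 3, `COc1ccc(/C=N/NC(=O)Nc2ccc(Oc3ccnc(-c4nncn4CCN(C)C)c3)c(F)c2)c(OC)c1OC`, 3970 nM

In a functional assay on HT-29 cells (Homo sapiens) for cytotoxicity, read by MTT assay, with a stated time of 72 h (on this read-out higher numbers stand for weaker inhibition and lower numbers for stronger inhibition), compound 3 gives the highest number of the three; the two steps leading up to it are an 8.8-fold higher number from compound 2 to compound 3 (0.95 log units; beyond the scatter) and a 14-fold higher number from compound 1 to compound 3 (1.15 log units; beyond the scatter), both beyond the scatter. Compound 4, `CN(C)CCn1cnnc1-c1cc(Oc2ccc(NC(=O)N/N=C/c3ccc(F)cc3F)cc2F)ccn1`, differs from compound 3 by 2,4-difluorophenyl in place of 2,3,4-trimethoxyphenyl on a carbon with a double bond to nitrogen. The two steps that bear on this change are the ones running the other way, from the halogenated aryl groups of compound 1 and compound 2 to the trimethoxyphenyl of compound 3, which were large. Since compound 4 carries a halogenated phenyl again, its number in this assay is expected to fall back toward the range of compound 1 and compound 2, a drop of about an 8.8-fold lower number from compound 3 to compound 4 (0.95 log units; beyond the scatter). Compound 4 is therefore estimated at 450 nM, with a range from 150 nM to 1400 nM.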

Compound 4, half-maximal inhibitory concentration: 960 nM
The estimate for compound 4 lay 2.1-fold (0.33 log units) below the measured number; the range from low to high includes it.
By their numbers in this assay, from the lowest: compounds 1 and 2 (each within the scatter of the next); then compound 4; then compound 3.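

In this assay, the 2,4-difluorophenyl group gives a 4.1-fold lower number from compound 3 to compound 4 (0.62 log units; beyond the scatter), yet this does not return the series to the level of the earlier halogenated aryl groups: the comparisons show a 2.1-fold higher number from compound 2 to compound 4 (0.33 log units; beyond the scatter) and a 3.4-fold higher number from compound 1 to compound 4 (0.54 log units; beyond the scatter). At this position, then, replacing 2,3,4-trimethoxyphenyl with a halogenated phenyl recovers only part of the gap, and the halogenated phenyl groups shown are not equivalent. Nothing measured here accounts for this order. The compounds shown leave open how a phenyl bearing a carboxylic acid or an amine would compare, and whether a single chlorine on the phenyl would behave more like compound 1 or compound 4.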